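The source may report more compounds than this note shows. Statements on the series, on what has been measured and on what is new or still open speak of the compounds shown alone.

Compound 1 `C#CCn1cc(C(=O)NCCCOC(=O)[C@H]2CCCN2C(=O)OC(C)(C)C)c(=O)c2ccc(Cl)nc21` carries a 1-(tert-butoxycarbonyl)pyrrolidin-2-yl group on a carbonyl carbon. In a functional assay on PA-1 cells (Homo sapiens) for cytotoxicity, read by MTT assay, with a stated time of 72 h (on this read-out higher numbers stand for weaker inhibition and lower numbers for stronger inhibition), compound 1 gives > 10000 nM, which is a limit of the assay rather than a measured number. Compound 2 `C#CCn1cc(C(=O)NCCCOC(=O)[C@H](C)NC(=O)OC(C)(C)C)c(=O)c2ccc(Cl)nc21` differs from compound 1 only in having 1-((tert-butoxycarbonyl)amino)ethyl in place of 1-(tert-butoxycarbonyl)pyrrolidin-2-yl on a carbonyl carbon. In this assay compound 2 gives > 10000 nM, again a limit of the assay. The step that the two limits leave unreadable from compound 1 to compound 2 cannot be read because of the limit of > 10000 nM in this assay, at which 2 of the 2 values shown sit. Compound 3 `C#CCn1cc(C(=O)NCCCOC(=O)[C@H]2CCCN2C(=O)OC(C)(C)C)c(=O)c2ccc(C)nc21` keeps the group of compound 1 and alters the shared core: methyl in place of chloro on an aromatic carbon. Among the measured compounds shown here, no measured step touches this change, and the only comparison available, from compound 1 to compound 2, is unreadable, so there is no basis for expecting a step in this assay beyond the scatter in either direction. The expected step in this assay is a step that the limit leaves unreadable from compound 1 to compound 3. Compound 3 is estimated at 15000 nM, with a range from 4000 nM to 60000 nM, and is expected most likely to remain at the limit.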

Compound 3, half-maximal inhibitory concentration: > 10000 nM
Compound 3: a limit, no number; the forecaster's own chance of this, stated with the estimate: 75%; the middle value lies beyond the limit too.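

No step can be read from compound 1 to compound 3, because both give a limit of the assay rather than a number in this assay: the limit of > 10000 nM in this assay, at which 3 of the 3 values shown sit. The compounds shown leave open whether methyl in place of chloro changes cytotoxicity at all, and which change to these structures would give a measurable value.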